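The compounds below may be only part of what the source reports. "The series", "measured", "known", "first", "only" and "open" are said of these compounds alone.

Measured compounds:
- compound 1, `CC(=O)Nc1ccc(OC(=S)Nc2ccc(Nc3ccc([N+](=O)[O-])cc3)cc2)cc1`: 4.32
- compound 2, `CC(=O)Nc1ccc(OC(=S)Nc2ccc(Nc3ccc(C(F)(F)F)cc3)cc2)cc1`: 5.32

In a physicochemical assay for lipophilicity (a higher number here means a more lipophilic compound, a lower number a more polar compound), compound 1 stands lowest of the two numbers; its nearest neighbour is compound 2, with a number 1.00 log units higher from compound 1 to compound 2 (beyond the scatter). Compound 3, `CC(=O)Nc1ccc(OC(=S)Nc2ccc(Sc3ccc([N+](=O)[O-])cc3)cc2)cc1`, differs from compound 1 by (4-nitrophenyl)sulfanyl in place of (4-nitrophenyl)amino on an aromatic carbon. Among the compounds with values here, no measured step touches this change; the one known step, a number 1.00 log units higher from compound 1 to compound 2 (beyond the scatter), alters a different group and is set aside. With a hydrogen-bond donor lost and sulfur entering, compound 3 is expected to run higher than compound 1, with a number 0.68 log units higher from compound 1 to compound 3 (beyond the scatter). The estimate for compound 3 in this assay is 5, within 4.5 to 5.5.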

Compound 3, partition coefficient: 5.06
Compound 3: the middle estimate sits 0.06 log units below what was measured; low and high end bracket the measured number.
By their numbers in this assay, from the lowest: compound 1; then compounds 3 and 2 (each within the scatter of the next).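

In this assay, the linking atom matters as well as the nitro end: with the nitro kept, (4-nitrophenyl)sulfanyl in place of (4-nitrophenyl)amino, on an aromatic carbon para to a large group, gives a step beyond the scatter (a number 0.74 log units higher from compound 1 to compound 3 (beyond the scatter)). No supporting evidence accounts for this step.

The pair cannot separate the entry of sulfur from the loss of the hydrogen-bond donor. On these data alone, an ether oxygen or a methylene link in this place remains open, as does the same exchange with trifluoromethyl in place of nitro.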